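Chloro in place of methyl: a fourth compound

The source may report more compounds than this note shows. Statements on the series, on what has been measured and on what is new or still open speak of the compounds shown alone.

Compound 1 `Cc1ccc(-c2nnc(NC(=O)/C=C/c3ccc(C(F)(F)F)cc3)s2)cc1` gives 1.61 ug/mL in a functional assay on A549 cells (Homo sapiens) for antiproliferative activity, read by MTT assay, with a stated time of 48 h; a higher number here means a weaker inhibitor, a lower number a stronger inhibitor. Compound 2 `O=C(/C=C/c1ccc(C(F)(F)F)cc1)Nc1nnc(-c2ccc(Cl)cc2)s1` gives 3.09 ug/mL in this assay; the difference between the two is chloro in place of methyl on an aromatic carbon, and the step is a 1.9-fold higher number from compound 1 to compound 2 (0.28 log units; within the scatter). Compound 3 `Cc1ccc(-c2nnc(NC(=O)/C=C/c3ccc(F)cc3)s2)cc1` gives 1.23 ug/mL in this assay; it differs from compound 1 by fluoro in place of trifluoromethyl on an aromatic carbon, the step being a 1.3-fold lower number from compound 1 to compound 3 (0.12 log units; within the scatter). Compound 4 `O=C(/C=C/c1ccc(F)cc1)Nc1nnc(-c2ccc(Cl)cc2)s1` is not yet measured. Within the data shown here, it differs from compound 3 by chloro in place of methyl on an aromatic carbon, the same change as the one between compound 1 and compound 2, made at the same place. The step expected in this assay is a 1.9-fold higher number from compound 3 to compound 4 (0.27 log units; within the scatter), set beside the measured 1.9-fold higher number from compound 1 to compound 2 (0.28 log units; within the scatter); it rests on that single paired step alone. For compound 4 the estimate is 2.3 ug/mL, expected to fall between 1.2 ug/mL and 4.5 ug/mL.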

Compound 4, half-maximal inhibitory concentration: 2.06 ug/mL
Beside the measured number, compound 4's estimate is 1.1-fold (0.05 log units) above it; low and high end bracket the measured number.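

In this assay, chloro in place of methyl gives a 1.7-fold higher number from compound 3 to compound 4 (0.22 log units; within the scatter), and this agrees with the earlier step on the other core: the same change on two cores in this assay, a 1.9-fold higher number (0.28 log units; within the scatter) from compound 1 to compound 2 and a 1.7-fold higher number (0.22 log units; within the scatter) from compound 3 to compound 4, 1.1-fold (0.06 log units) apart, within the scatter of two such steps. Fluoro in place of trifluoromethyl gives a 1.5-fold lower number from compound 2 to compound 4 (0.18 log units; within the scatter), and this also agrees with its earlier counterpart: the same change on two cores in this assay, a 1.3-fold lower number (0.12 log units; within the scatter) from compound 1 to compound 3 and a 1.5-fold lower number (0.18 log units; within the scatter) from compound 2 to compound 4, 1.1-fold (0.06 log units) apart, within the scatter of two such steps. Across these four compounds, each change reads the same on both cores, but every step lies within the scatter, so this does not show that either change shifts the number, nor that the agreement would hold on any other core.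

Still open, going by these compounds, is how an amine or a carboxylic acid in place of the methyl would read. The same applies to a longer chain in place of the fluoro.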